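Lengthening the Chain on the Ring Nitrogen

The compounds below may be only part of what the source reports. "The series", "measured", "known", "first", "only" and "open" are said of these compounds alone.

Compound 2 `CCn1c(=O)c(-c2cccc([N+](=O)[O-])c2)nc2ccccc21` carries an ethyl on the aromatic nitrogen of the shared core. Within the data shown here, in an assay on cells for activation of Cystic fibrosis transmembrane conductance regulator (Homo sapiens), read by fluorescence, with a stated time of 10 min (on this read-out lower numbers stand for an effect already at smaller amounts and higher numbers for an effect only at larger amounts of compound), compound 2 gives 65 nM, the only plain number among the values shown. Compound 1 `Cn1c(=O)c(-c2cccc([N+](=O)[O-])c2)nc2ccccc21` gives only a limit of > 10000 nM in this assay. The step of an at least 150-fold lower number from compound 1 to compound 2 (2.18 log units; beyond the scatter) is open-ended because compound 1 sits at the limit of > 10000 nM in this assay, at which 1 of the 2 values shown sits. Compound 3 `CCCn1c(=O)c(-c2cccc([N+](=O)[O-])c2)nc2ccccc21` is not yet measured; it differs from compound 2 by methyl in place of hydrogen on a saturated chain carbon, two bonds along the chain from an aromatic nitrogen. Among the measured compounds shown here, the single measured step, from compound 1 to compound 2, is the same kind of change one bond closer to the aromatic nitrogen, and it was large. For the measured compounds named here, no second step tells whether growth further out keeps that gain, so the expectation is a small change in this assay, with a modest gain judged somewhat more likely than a loss. The expected outcome is a 1.6-fold lower number from compound 2 to compound 3 (0.21 log units; within the scatter). Compound 3 is estimated at 40 nM, between 10 nM and 250 nM.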

Compound 3, half-maximal effective concentration: 177 nM
Compound 3: the middle estimate sits 4.4-fold (0.65 log units) below what was measured; low and high end bracket the measured number.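

The position does not reward chain length without end. In this assay, the methyl placed two bonds along the chain from the aromatic nitrogen gives a 2.7-fold higher number from compound 2 to compound 3 (0.44 log units; beyond the scatter), so the same kind of change that brought a large gain closer to that nitrogen here brings a modest loss, and among the three chains the ethyl of compound 2 stands best. The propyl chain still keeps a large advantage over the shortest chain, an at least 56-fold lower number from compound 1 to compound 3 (1.75 log units; beyond the scatter), and this step is open-ended because it is read against a limit: the limit of > 10000 nM in this assay, at which 1 of the 3 values shown sits.

The compounds shown do not tell whether the trend continues with a longer chain such as butyl. Nor do they tell how a branched chain such as isopropyl, or a chain ending in a hydroxyl or an amine, would compare with ethyl.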